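Nitro for Methyl: Estimating Compound 4 from Compound 2

The source may report more compounds than this note shows. Statements on the series, on what has been measured and on what is new or still open speak of the compounds shown alone.

Compound 1, `CCC(C)C(C(=O)Nc1ccc(C(C)=O)cc1)N(C(=O)c1ccccc1)S(=O)(=O)c1ccc(C)cc1`, in a functional assay for inhibition, read by spectrophotometry, with a stated time of 20 min, tested at 1 mg/mL (a lower number here means a weaker effect, a higher number a stronger effect of the compound at the concentration tested), gives 18.6%.
Compound 2, `CC(=O)c1ccc(NC(=O)C2CC(O)CN2S(=O)(=O)c2ccc(C)cc2)cc1`, in this assay gives 12.4%.
Compound 3, `CCC(C)C(C(=O)Nc1ccc(C(C)=O)cc1)N(C(=O)c1ccccc1)S(=O)(=O)c1ccc([N+](=O)[O-])cc1`, in this assay gives 28.6%.

Compound 3 differs from compound 1 by nitro in place of methyl on an aromatic carbon, and this step measured a number 10 percentage points higher from compound 1 to compound 3 (within the scatter). The difference between the core of compound 1 and the core of compound 2 is not broken down here. Compound 4, `CC(=O)c1ccc(NC(=O)C2CC(O)CN2S(=O)(=O)c2ccc([N+](=O)[O-])cc2)cc1`, has not yet been measured; it differs from compound 2 by nitro in place of methyl on an aromatic carbon, the same change as from compound 1 to compound 3 at the same kind of place. Because the measured step was a number 10 percentage points higher from compound 1 to compound 3 (within the scatter), a step of similar size is expected on the core of compound 2, namely a number 7.6 percentage points higher from compound 2 to compound 4 (within the scatter). Compound 4 is therefore estimated at 20%, with a range expected from 8% to 34%.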

Compound 4, a percentage reported as inhibition, at one concentration (the size of the read-out at that concentration, not a potency): 43.2%
The estimate for compound 4 lay 23.2 percentage points below the measured number; measured number outside the range, above it.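

In this assay, nitro in place of methyl on an aromatic carbon gives a number 30.8 percentage points higher from compound 2 to compound 4 (beyond the scatter). The size of the step did not carry from one core to the other, so the step seen on the core of compound 1 was no reliable guide on the core of compound 2: the same change on two cores in this assay, a number 10 percentage points higher (within the scatter) from compound 1 to compound 3 and a number 30.8 percentage points higher (beyond the scatter) from compound 2 to compound 4, 20.8 percentage points apart, beyond the scatter of two such steps This does not show which part of the two cores goes with the larger step, and two pairs set no rule for the series.

The compounds shown carry only methyl or nitro at this place on the ring, so how an amine, a nitrile or a chlorine atom there would read in this assay stays open. From the compounds shown here alone, whether the step would hold its size on any third core also stays open.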